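This account rests on a few compounds, and the source may have more. Where it says the series, first, only, none or still open, it means among the compounds named here.

Measured compounds in a functional assay on CHO cells for inhibition of metabotropic glutamate receptor 5 (Rattus norvegicus), read by FLIPR and calcium flux; on this read-out higher numbers stand for weaker inhibition and lower numbers for stronger inhibition:
Compound 1 `COc1cc(C#N)cc(-c2ccc3ccc(C)nc3c2)c1` gives 2.4 nM
Compound 2 `Cc1ccc2ccc(-c3cc(Br)cc(C#N)c3)cc2n1` gives 13 nM
Compound 3 `Cc1ccc2ccc(-c3cc(C#N)cc(OC(C)C)c3)cc2n1` gives 310 nM

Compound 3 stands at the highest of the three numbers in this assay: the step of a 130-fold higher number from compound 1 to compound 3 (2.11 log units; beyond the scatter) is large, and so is a 24-fold higher number from compound 2 to compound 3 (1.38 log units; beyond the scatter). Compound 4 `Cc1ccc2ccc(-c3cc(C#N)cc(OCC(C)C)c3)cc2n1` differs from compound 3 by isobutyl in place of isopropyl on an oxygen on an aromatic ring. Within the data shown here, of the measured steps, only one changes the group on that oxygen: a 130-fold higher number from compound 1 to compound 3 (2.11 log units; beyond the scatter), where a larger alkyl brought a large rise in the number. The other step, a 5.4-fold higher number from compound 1 to compound 2 (0.73 log units; beyond the scatter), concerns a different position and does not bear on this change. With a single step at the same place, the expectation for compound 4 rests on that one comparison: the number is expected to stay near compound 3 or move somewhat higher, a 1.9-fold higher number from compound 3 to compound 4 (0.29 log units; within the scatter), with wide uncertainty. Compound 4 is therefore estimated at 600 nM in this assay, within a range from 150 nM to 3000 nM.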

Compound 4, half-maximal inhibitory concentration: 12000 nM
The estimate for compound 4 lay 20-fold (1.30 log units) below the measured number; the measured number lies above the stated range.
By their numbers in this assay, from the lowest: compound 1; then compound 2; then compound 3; then compound 4.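

In this assay, among these compounds, the group on the oxygen proves far more sensitive than the earlier compounds could show: isobutyl in place of isopropyl, a small change, gives a large step (a 39-fold higher number from compound 3 to compound 4 (1.59 log units; beyond the scatter)). Across the three ethers, the number rises from methyl through isopropyl to isobutyl, with no compound going against this order, and the full span is very large (a 5000-fold higher number from compound 1 to compound 4 (3.70 log units; beyond the scatter)); isobutoxy in place of bromo also gives a large step (a 920-fold higher number from compound 2 to compound 4 (2.97 log units; beyond the scatter)). No measurement available here explains why this small change has so large an effect.

On these data alone, whether the rise follows chain length or branching remains open, as does what a straight butyl chain would give. Also open, as far as these compounds go, is whether an ethyl group would fall between methyl and isopropyl, and whether an amine at the end of the chain would change the trend.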